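The source may report more compounds than this note shows. Statements on the series, on what has been measured and on what is new or still open speak of the compounds shown alone.

Working notes on the series. The shared core of compound 1 `O=C(/C=C\Nc1ccc(O)cc1)c1cn(-c2ccccc2)nc1-c1ccccc1` is kept across the set; compound 2 `O=C(/C=C\Nc1ccc(F)cc1)c1cn(-c2ccccc2)nc1-c1ccc(Cl)cc1` and compound 3 `COc1ccc(-c2nn(-c3ccccc3)cc2C(=O)/C=C\Nc2ccc(F)cc2)cc1` carry a fluoro on the aniline ring and differ from each other only on the distal aryl ring. In a functional assay on U-87MG ATCC cells (Homo sapiens) for antiproliferative activity, read by MTT assay, with a stated time of 48 h (on this read-out lower numbers stand for stronger inhibition and higher numbers for weaker inhibition), compound 1 gives 4290 nM, compound 2 gives 17900 nM, and compound 3 gives 8910 nM. Among the measured compounds shown here, compound 3 thus stands second highest of the three numbers; the one measured step, a 2.0-fold lower number from compound 2 to compound 3 (0.30 log units; within the scatter), is within the scatter, whereas the gap to compound 1 is beyond it.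

Compound 4 `COc1ccc(-c2nn(-c3ccccc3)cc2C(=O)/C=C\Nc2ccc(O)cc2)cc1` is not yet measured. It differs from compound 3 by hydroxy in place of fluoro on an aromatic carbon. For the measured compounds named here, no measured pair isolates this change: compound 1 also carries the hydroxy on the aniline ring, but it differs from compound 2 in two places, so its lower number relative to compound 2 cannot be assigned to the hydroxy alone. Going by the values given here, the single measured step, from chloro to methoxy, does not bear on the aniline ring. Only a modest move toward the lower number of compound 1 is expected, with wide uncertainty.

For compound 4 in this assay the estimated value is 4500 nM, with a range of 1500 nM to 13000 nM, which is expected to amount to a step of a 2.0-fold lower number from compound 3 to compound 4 (0.30 log units; within the scatter).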

Compound 4, half-maximal inhibitory concentration: 3730 nM
Beside the measured number, compound 4's estimate is 1.2-fold (0.08 log units) above it, within the range that was stated.
By their numbers in this assay, from the lowest: compounds 4 and 1 (each within the scatter of the next); then compounds 3 and 2 (each within the scatter of the next).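

The change from (4-fluorophenyl)amino to (4-hydroxyphenyl)amino now has a pair of its own: in this assay it gives a 2.4-fold lower number from compound 3 to compound 4 (0.38 log units; beyond the scatter) and so, unlike the earlier comparison of compound 1 with compound 2, which differ in two places, it can be assigned to this one position. The step is modest, but it lies beyond the scatter, and it stands apart from the chloro-to-methoxy step, which stayed within the scatter. With the hydroxy present, methoxy in place of hydrogen gives a 1.2-fold lower number from compound 1 to compound 4 (0.06 log units; within the scatter) and therefore does not separate the two compounds, while no data at hand account for the effect of the hydroxy at this position.

Among the compounds shown, only fluoro and hydroxy occupy this position, so how an amine, a carboxylic acid or a longer chain such as ethoxy would read there remains open. Also open, going by these compounds, is whether the same change gives a similar step when chloro replaces methoxy on the distal aryl ring.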